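The source may hold more compounds than are shown below. What is called first, only, known or untested is meant among the compounds shown, and "the series" means these compounds.

Measured in a functional assay on MGC-803 cells (Homo sapiens) for cytotoxicity, read by MTT assay, with a stated time of 72 h; on this read-out lower numbers stand for stronger inhibition and higher numbers for weaker inhibition:
Compound 1 `O=C1C(=Cc2ccc(O)cc2)C(=O)N(c2ccc(Cl)cc2)N1c1ccc(Cl)cc1`: 19500 nM
Compound 2 `COc1cc(C=C2C(=O)N(c3ccc(Cl)cc3)N(c3ccc(Cl)cc3)C2=O)ccc1O`: 21800 nM
Compound 3 `O=C1C(=Cc2cccc(Cl)c2)C(=O)N(c2ccc(Cl)cc2)N1c1ccc(Cl)cc1`: 14400 nM

Compound 3, at 14400 nM, stands level with the other two compounds, and all three values lie within the scatter of one another. Compound 4 `COc1ccccc1C=C1C(=O)N(c2ccc(Cl)cc2)N(c2ccc(Cl)cc2)C1=O` has 2-methoxyphenyl in place of 3-chlorophenyl on a double-bonded chain carbon bound to a double-bonded ring carbon. For the measured compounds named here, three measured steps bear on this. Two swap the group at that same place, a 1.4-fold lower number from compound 1 to compound 3 (0.13 log units; within the scatter) and a 1.5-fold lower number from compound 2 to compound 3 (0.18 log units; within the scatter). The third adds a methoxy group, a 1.1-fold higher number from compound 1 to compound 2 (0.05 log units; within the scatter). All three stay within the scatter, so no step beyond it is expected in this assay. The expected change is a 1.2-fold higher number from compound 3 to compound 4 (0.07 log units; within the scatter). The estimate for compound 4 is 17000 nM, with an expected range of 8000 nM to 35000 nM.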

Compound 4, half-maximal inhibitory concentration: 28600 nM
For compound 4 the middle estimate is 1.7-fold (0.23 log units) below the measured one; the range from low to high includes it.
By their numbers in this assay, from the lowest: compounds 3, 1, 2 and 4 (each within the scatter of the next).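

In this assay, 2-methoxyphenyl at this place gives a 2.0-fold higher number from compound 3 to compound 4 (0.30 log units; within the scatter), a 1.3-fold higher number from compound 2 to compound 4 (0.12 log units; within the scatter) and a 1.5-fold higher number from compound 1 to compound 4 (0.17 log units; within the scatter). For the compounds shown here, this is the first aromatic group here with a methoxy group and neither hydroxy nor chlorine on its ring, and it still stays within the scatter of all three earlier compounds. No measurement shown offers an explanation for these small differences.

As far as these compounds go, whether an amine or a carboxylic acid on this ring would move the number beyond the scatter remains open. So does the effect of any change elsewhere on the shared core.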